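The source may hold more compounds than are shown below. What is called first, only, known or untested is meant among the compounds shown, and "the series" means these compounds.

Measured so far:
compound 1 `COc1ccc(Cn2cc(CNC(=O)c3ccc([N+](=O)[O-])o3)nn2)cc1F` with 312000 nM
compound 2 `O=C(NCc1cn(Cc2ccc([N+](=O)[O-])cc2)nn1)c1ccc([N+](=O)[O-])o1` with 291000 nM

Both numbers come from an ADME assay on Vero cells (Chlorocebus sabaeus) for cytotoxicity; a lower number here means a stronger inhibitor, a higher number a weaker inhibitor. Compound 1 gives 312000 nM and compound 2 gives 291000 nM; the two sit within the usual scatter of each other, so neither stands apart, and the step of a 1.1-fold lower number from compound 1 to compound 2 (0.03 log units; within the scatter) is one that could as well be repeat-to-repeat noise. Compound 3 `COc1cc(Cn2cc(CNC(=O)c3ccc([N+](=O)[O-])o3)nn2)ccc1O` has not yet been measured in this assay. It differs from compound 2 in one place: 4-hydroxy-3-methoxyphenyl in place of 4-nitrophenyl on a saturated chain carbon bound to an aromatic nitrogen. Among the measured compounds shown here, the only step on record that bears on this swap is the one from compound 1 to compound 2, which also replaced the group on that same saturated chain carbon, and it was a 1.1-fold lower number from compound 1 to compound 2 (0.03 log units; within the scatter). That single step, lying within the scatter, gives no sign that the group at this position moves the number in this assay, so no step beyond the scatter is expected here. On that basis compound 3 is expected to come out at 300000 nM, with a range from 150000 nM to 600000 nM. The expected step from compound 2 to compound 3 is therefore a 1.0-fold higher number from compound 2 to compound 3 (0.01 log units; within the scatter), a change of no real size.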

Compound 3, half-maximal inhibitory concentration: 224000 nM
The estimate for compound 3 lay 1.3-fold (0.13 log units) above the measured number; the measured number falls inside the stated range.
By their numbers in this assay, from the lowest: compounds 3, 2 and 1 (each within the scatter of the next).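

In this assay, the group on a saturated chain carbon bound to an aromatic nitrogen has now been varied across three forms, and the readings still do not separate: putting 4-hydroxy-3-methoxyphenyl in place of 4-nitrophenyl gives a 1.3-fold lower number from compound 2 to compound 3 (0.11 log units; within the scatter), and putting it in place of 3-fluoro-4-methoxyphenyl gives a 1.4-fold lower number from compound 1 to compound 3 (0.14 log units; within the scatter) as well. The new group brings a hydrogen-bond donor where 4-nitrophenyl has none, and among these three compounds even that change produces no step beyond the scatter, which extends the single earlier comparison to a second and a third pair. No measurement shown offers a reason for this flat result.

On these data alone, all three groups are substituted phenyl rings, so it remains open whether the number would hold with a different kind of group on this carbon, such as an amine, a carboxylic acid or a longer chain. The compounds shown also leave open whether a change elsewhere in the shared core, for instance at its amide, would move the number in this assay at all.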